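The source may hold more compounds than are shown below. What is called first, only, known or untested is meant among the compounds shown, and "the series" means these compounds.

Three compounds measured so far in a functional assay on SMMC-7721 cells (Homo sapiens) for antiproliferative activity, read by MTT assay, with a stated time of 48 h; on this read-out higher numbers stand for weaker inhibition and lower numbers for stronger inhibition:

- Compound 1 `COC/C1=C/C[C@](C)(CCC=C(C)C)/C=C/[C@@H](OC(=O)C=C(C)C)[C@](C)(O)/C=C/C1=O` gives 11000 nM
- Compound 2 `CC(C)=CCC[C@]1(C)/C=C/[C@@H](OC(=O)C=C(C)C)[C@](C)(O)/C=C/C(=O)/C(CCl)=C\C1` gives 840 nM
- Compound 3 `CCN(CC)C/C1=C/C[C@](C)(CCC=C(C)C)/C=C/[C@@H](OC(=O)C=C(C)C)[C@](C)(O)/C=C/C1=O` gives 570 nM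

Compound 3 stands at the low end of these numbers, level with compound 2. The gap between them, a 1.5-fold lower number from compound 2 to compound 3 (0.17 log units; within the scatter), does not separate the two, whereas a 19-fold lower number from compound 1 to compound 3 (1.29 log units; beyond the scatter) is a clear one.

Compound 4 `CC(C)=CCC[C@]1(C)/C=C/[C@@H](OC(=O)C=C(C)C)[C@](C)(O)/C=C/C(=O)/C(CN2CCN(C)CC2)=C\C1` keeps the shared core and carries 4-methylpiperazin-1-yl in place of diethylamino on a saturated chain carbon bound to a double-bonded ring carbon.

For the measured compounds named here, all the measured steps changed this same place. Methoxy gave way to chloro in a 13-fold lower number from compound 1 to compound 2 (1.12 log units; beyond the scatter), a large step, and to diethylamino in a 19-fold lower number from compound 1 to compound 3 (1.29 log units; beyond the scatter), also large. Replacing chloro with diethylamino in a 1.5-fold lower number from compound 2 to compound 3 (0.17 log units; within the scatter) changed little. Going by the values given here, no measured pair compares one amino group with another, so the guide is weak. With methoxy absent from compound 4, a large step seems unlikely in this assay. The expected step is a 1.4-fold higher number from compound 3 to compound 4 (0.15 log units; within the scatter), so no shift beyond the scatter is anticipated.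

The estimate for compound 4 is 800 nM, with an expected range from 250 nM to 2500 nM.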

Compound 4, half-maximal inhibitory concentration: 2940 nM
Beside the measured number, compound 4's estimate is 3.7-fold (0.57 log units) below it; the whole stated range lies below it.
By their numbers in this assay, from the lowest: compounds 3 and 2 (each within the scatter of the next); then compound 4; then compound 1.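

In this assay, the place on a saturated chain carbon bound to a double-bonded ring carbon now separates one amino group from another: 4-methylpiperazin-1-yl in place of diethylamino gives a 5.2-fold higher number from compound 3 to compound 4 (0.71 log units; beyond the scatter), so the kind of amine matters here, not only the presence of one. The same group gives a 3.5-fold higher number from compound 2 to compound 4 (0.54 log units; beyond the scatter) and a 3.7-fold lower number from compound 1 to compound 4 (0.57 log units; beyond the scatter), which puts compound 4 at neither end of the series. No measurement here explains why the two amino groups differ.

The compounds shown do not tell whether the ring itself or its second nitrogen goes with the higher number. A piperidine ring, which keeps the ring without that nitrogen, or a morpholine ring, with oxygen in its place, would separate the two.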